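The compounds below may be only part of what the source reports. "The series", "measured", "known", "first", "only" and "open" are said of these compounds alone.

Compound 3 `COC(=O)c1cnc(C(O)CCCCCCc2ccccc2)o1` gives the highest number of the three in an assay (Rattus norvegicus) for inhibition of Fatty-acid amide hydrolase 1 (Homo sapiens) (on this read-out higher numbers stand for weaker inhibition and lower numbers for stronger inhibition), at 2000 nM; compound 1 `N#Cc1ccccc1-c1cnc(C(=O)CCCCCCc2ccccc2)o1` gives 130 nM and compound 2 `COc1ccnc(-c2cnc(C(=O)CCCCCCc3ccccc3)o2)c1` gives 0.8 nM. Compound 4 `O=C(O)c1ccc(-c2cnc(C(O)CCCCCCc3ccccc3)o2)nc1` differs from compound 3 by 5-carboxypyridin-2-yl in place of methoxycarbonyl on an aromatic carbon. Within the data shown here, the only measured step at that place, a 160-fold lower number from compound 1 to compound 2 (2.21 log units; beyond the scatter), exchanges one aryl group for another on the ketone-bearing core, whereas compound 3 carries an alcohol; no step converts a methoxycarbonyl to an aryl group, and no step joins the alcohol series to the ketone series. A pyridyl group at this position is therefore expected to lower the number, but by less than the full span seen in this assay. Compound 4 is estimated at 300 nM in this assay, within 40 nM to 2500 nM, corresponding to an expected step of a 6.7-fold lower number from compound 3 to compound 4 (0.82 log units; beyond the scatter).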

Compound 4, inhibition constant: 45000 nM
Compound 4: the middle estimate sits 150-fold (2.18 log units) below what was measured; measured number outside the range, above it.
By their numbers in this assay, from the lowest: compound 2; then compound 1; then compound 3; then compound 4.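

In this assay, 5-carboxypyridin-2-yl in place of methoxycarbonyl gives a 23-fold higher number from compound 3 to compound 4 (1.35 log units; beyond the scatter), so a pyridine ring on this aromatic carbon does not by itself lower the number. This step runs opposite to a 160-fold lower number from compound 1 to compound 2 (2.21 log units; beyond the scatter), which belongs to the ketone-bearing core and a different pair of groups. Nothing available accounts for the rise.

Open: how the methyl ester of this carboxylic acid, or an unsubstituted pyridin-2-yl, would read on this carbon. Going by these compounds, also open: whether a ketone in place of the alcohol would alter the effect of 5-carboxypyridin-2-yl.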